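The compounds below may be only part of what the source reports. "The series", "measured", "known", "first", "only" and "open" are said of these compounds alone.

Of the compounds shown here, three of one shared core have been measured in an assay on isolated protein for inhibition of Caspase-8 (Homo sapiens); on this read-out higher numbers stand for weaker inhibition and lower numbers for stronger inhibition. Compound 1 `COc1cccc(C(=O)NNC(=O)C2(C(=O)N[C@H]3CC(=O)OC3O)CCC2)c1` gives 2200 nM in this assay. Compound 2 `O=C1C[C@H](NC(=O)C2(C(=O)NNC(=O)c3ccc4ccccc4c3)CCCC2)C(O)O1` gives 3200 nM. Compound 3 `COc1cccc(C(=O)NNC(=O)C2(C(=O)N[C@H]3CC(=O)OC3O)CCCCC2)c1` gives 1800 nM, and its gaps to compound 1 and to compound 2 both lie within the usual scatter, so none of the three can be told apart on these numbers.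

Compound 4 `Cc1cccc(C)c1C(=O)NNC(=O)C1(C(=O)N[C@H]2CC(=O)OC2O)CCCCC1` is not yet measured. It differs from compound 3 in one place: 2,6-dimethylphenyl in place of 3-methoxyphenyl on a carbonyl carbon. Going by the values given here, no measured pair shows this change, so there is nothing to scale an expectation from; the step from compound 3 to compound 4 is expected to be a 1.4-fold higher number from compound 3 to compound 4 (0.14 log units; within the scatter), small and within the scatter. Compound 4 is estimated at 2500 nM, between 1000 nM and 6500 nM.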

Compound 4, half-maximal inhibitory concentration: 230 nM
The estimate for compound 4 lay 11-fold (1.04 log units) above the measured number; the measured number lies below the stated range.
By their numbers in this assay, from the lowest: compound 4; then compounds 3, 1 and 2 (each within the scatter of the next).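

In this assay, going by these compounds alone, the group on this carbonyl carbon clearly matters: 2,6-dimethylphenyl in place of 3-methoxyphenyl gives a 7.8-fold lower number from compound 3 to compound 4 (0.89 log units; beyond the scatter) and is the first step in this set beyond the scatter. Within the data shown here, the three earlier compounds lay within the scatter of one another and gave no sign that a change here could shift the number so far.

From the compounds shown here alone, whether a plain phenyl, a 2-methylphenyl or a 2,6-dichlorophenyl would give a similar step remains open. Nothing measured here gives a reason for the step.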